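From propanoyl to acetyl at the assay limit

This account rests on a few compounds, and the source may have more. Where it says the series, first, only, none or still open, it means among the compounds named here.

Measured in a functional assay on HT-29 cells (Homo sapiens) for inhibition, read by MTT assay, with a stated time of 96 h; a higher number here means a weaker inhibitor of growth, a lower number a stronger inhibitor of growth:
- Compound 1 `CC(C)C(=O)SCCCCCCNC(=O)c1cc(-c2ccncc2)n[nH]1`: 25700 nM
- Compound 2 `CCC(=O)SCCCCCCNC(=O)c1cc(-c2ccncc2)n[nH]1`: > 50000 nM (a limit of the assay, not a number)

Compound 2 therefore has no exact position on the scale, and its reading in this assay stands only as a limit. Compound 3 `CC(=O)SCCCCCCNC(=O)c1cc(-c2ccncc2)n[nH]1` has not yet been measured. It differs from compound 2 by a single change, (hydrogen in place of methyl on a saturated chain carbon bound to a carbonyl carbon), which turns propanoyl into acetyl.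

Within the data shown here, only one measured step bears on this change. That step is an at least 1.9-fold higher number from compound 1 to compound 2 (0.28 log units; that floor lies within the scatter), and it involved the same replacement of methyl by hydrogen on a saturated chain carbon bound to a carbonyl carbon. A single step with an open upper end gives only weak guidance. Going by an at least 1.9-fold higher number from compound 1 to compound 2 (0.28 log units; that floor lies within the scatter), no shift beyond the scatter is firmly expected in this assay, and any shift is expected to be towards a higher number.

The expected change is a step that the limit leaves unreadable from compound 2 to compound 3. Compound 3 is estimated at 55000 nM, with an expected range of 25000 nM to 120000 nM, and it may well be reported only as a limit.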

Compound 3, concentration for 50% growth inhibition: 23100 nM
Compound 3: middle estimate off by 2.4-fold (0.38 log units), on the high side; the whole stated range lies above it.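

In this assay, the change from propanoyl to acetyl gave a step that can be read, an at least 2.1-fold lower number from compound 2 to compound 3 (0.33 log units; beyond the scatter), and this floor lies beyond the scatter. The same replacement of methyl by hydrogen on a saturated chain carbon bound to a carbonyl carbon had earlier given an at least 1.9-fold higher number from compound 1 to compound 2 (0.28 log units; that floor lies within the scatter), a floor within the scatter, so the two steps point in opposite directions and this change has no single direction across the compounds shown. Methyl in place of isopropyl on a carbonyl carbon gives a 1.1-fold lower number from compound 1 to compound 3 (0.05 log units; within the scatter), which places compound 1 and compound 3 within the scatter of each other, and compound 2, with propanoyl, is the one that goes against any steady trend along this series.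

From the compounds shown here alone, how far compound 2 lies past its reading stays unknown, as that reading is a limit and not a number: the limit of > 50000 nM in this assay, at which 1 of the 3 values shown sits. Also open is how a longer chain such as pentanoyl, or an amine on the carbon bound to the carbonyl carbon, would read in this assay.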